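The source may report more compounds than this note shows. Statements on the series, on what has been measured and on what is new or still open speak of the compounds shown alone.

Measured so far in an assay on isolated protein for inhibition of leukotriene B4 receptor 1 (Homo sapiens), tested at 10 uM; a lower number here means less inhibition, a higher number more inhibition at the concentration tested (going by the name of the read-out): compound 1 `CC(=O)c1ccc(OCCCCC#N)cc1O` gives 0%; compound 2 `CC(=O)c1cc(C)c(OCCCCC#N)cc1O` gives 79%.

Compound 2 stands highest of the two numbers, its nearest neighbour being compound 1, and the step of a number 79 percentage points higher from compound 1 to compound 2 (beyond the scatter) came with methyl in place of hydrogen on an aromatic carbon. Compound 3 `CCc1cc(C(C)=O)c(O)cc1OCCCCC#N` differs from compound 2 by methyl in place of hydrogen on a saturated chain carbon bound to an aromatic carbon. For the measured compounds named here, the only measured step, a number 79 percentage points higher from compound 1 to compound 2 (beyond the scatter), bears on it indirectly, since it touches the same group one bond further in; a second methyl added there is expected to change little, so compound 3 is expected to show a number 9 percentage points lower from compound 2 to compound 3 (within the scatter), a step not beyond the scatter. Compound 3 is therefore estimated at 70%, with a range of 40% to 95%.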

Compound 3, a percentage reported as inhibition, at one concentration (the size of the read-out at that concentration, not a potency): 92%
Beside the measured number, compound 3's estimate is 22 percentage points below it; low and high end bracket the measured number.
By their numbers in this assay, from the lowest: compound 1; then compound 2; then compound 3.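

In this assay, the methyl to ethyl change gave a number 13 percentage points higher from compound 2 to compound 3 (beyond the scatter) and so the position still responds past the first methyl. Measured against hydrogen, ethyl on this aromatic carbon gives a number 92 percentage points higher from compound 1 to compound 3 (beyond the scatter) as the whole change at this place. Nothing available accounts for this response. On these data alone, whether a longer chain such as propyl or butyl would raise the inhibition further or lose it stays open. So does whether a chlorine atom or a methoxy group could stand in for ethyl at this place.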